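Chloro on the pendant phenyl of a thione-bearing core

This account rests on a few compounds, and the source may have more. Where it says the series, first, only, none or still open, it means among the compounds named here.

Compound 1 `N=c1sc(=S)[nH]c2c1cc(-c1ccccc1)n2-c1ccccc1` and compound 2 `N=c1sc(=S)[nH]c2c1cc(-c1ccc(Cl)cc1)n2-c1ccccc1` share one core. In a functional assay on the whole organism for inhibition, with Rattus norvegicus as the target, read by ELISA, with stated times of 30 min and 6 h, at a dose of 30 mg/kg by the oral route (a higher number here means more inhibition at the dose given (going by the name of the read-out), a lower number less inhibition), compound 1 gives 0% and compound 2 gives 2%. The step of a number 2 percentage points higher from compound 1 to compound 2 (within the scatter) corresponds to the change (chloro in place of hydrogen on an aromatic carbon).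

Compound 3 `N=c1c2cc(-c3ccccc3)n(-c3ccccc3)c2[nH]c(=S)n1N` is built on a different core; how its core differs from that of compound 1 is not broken down here. In this assay compound 3 gives 23%, the highest of the three numbers, and its gap to both compound 1 and compound 2 lies beyond the scatter.

Compound 4 `N=c1c2cc(-c3ccc(Cl)cc3)n(-c3ccccc3)c2[nH]c(=S)n1N` has not yet been measured. It differs from compound 3 by chloro in place of hydrogen on an aromatic carbon, the same kind of change as that from compound 1 to compound 2, made in the same place on the same ring. The earlier step stayed within the scatter, so the expected step of a number 2 percentage points higher from compound 3 to compound 4 (within the scatter) rests on the assumption that the change behaves alike on the core of compound 3, whose value is 23%. Compound 4 is therefore expected to give about 25% in this assay, estimated between 10% and 40%.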

Compound 4, a percentage reported as inhibition, in the whole organism at one dose (the size of the read-out at that dose, not a potency): 0%
Beside the measured number, compound 4's estimate is 25 percentage points above it; the whole stated range lies above it.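

On the core of compound 3, the change from phenyl to 4-chlorophenyl gives in this assay a number 23 percentage points lower from compound 3 to compound 4 (beyond the scatter), whereas on the core of compound 1 the same change gives a number 2 percentage points higher from compound 1 to compound 2 (within the scatter). The change therefore did not carry over unaltered from one core to the other, and the step seen on one core could not be relied on to predict the step on the other: the same change on two cores in this assay, a number 2 percentage points higher (within the scatter) from compound 1 to compound 2 and a number 23 percentage points lower (beyond the scatter) from compound 3 to compound 4, 25 percentage points apart, beyond the scatter of two such steps These two pairs do not show what in the cores sets the steps apart or how the change would behave on any third core, and as readings at a single oral dose they describe the size of inhibition at that dose, not potency.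

As far as these compounds go, it remains open whether fluoro, methoxy or a carboxylic acid in place of the chloro would retain the inhibition seen with compound 3. Also open, from the compounds shown here alone, is whether chloro on the other phenyl group would produce a similar step on either core.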